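Compound 3 to compound 4: hydroxy on the benzyl group

The compounds below may be only part of what the source reports. "The series", "measured", "known", "first", "only" and "open" are said of these compounds alone.

In a functional assay on RS4-11 cells (Homo sapiens) for inhibition, read by CCK-8 assay, with a stated time of 48 h (a lower number here means a stronger inhibitor, a higher number a weaker inhibitor), compound 1 `O=S(=O)(NCCNC(=S)Nc1cccc(Cl)c1)c1ccc(-c2ccccc2OCc2cccc(O)c2)s1` gives 5800 nM. Compound 2 `O=C(NCCNS(=O)(=O)c1ccc(-c2ccccc2OCc2cccc(O)c2)s1)Nc1cc(Cl)cc(Cl)c1` gives > 50000 nM, which is a limit of the assay and not a number. Compound 3 `O=[N+]([O-])c1ccc(NC(=S)NCCNS(=O)(=O)c2ccc(-c3ccccc3OCc3ccccc3)s2)cc1` gives 11300 nM, and this value lies within the scatter of compound 1 at 5800 nM. The two cannot be ranked, and the only other result is the limit.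

Compound 4 `O=[N+]([O-])c1ccc(NC(=S)NCCNS(=O)(=O)c2ccc(-c3ccccc3OCc3cccc(O)c3)s2)cc1` differs from compound 3 by hydroxy in place of hydrogen on an aromatic carbon, turning benzyl into 3-hydroxybenzyl. Among the compounds with values here, the only measured step is an at least 8.6-fold higher number from compound 1 to compound 2 (0.93 log units; beyond the scatter). It lies beyond the scatter, but it concerns the group on the amine nitrogen, and both of its compounds already carry the 3-hydroxybenzyl. Within the data shown here, it therefore says nothing direct about this change, and no measured pair isolates the hydroxy. The nearest guide is compound 1 at 5800 nM, which carries the 3-hydroxybenzyl and still sits within the scatter of compound 3, though its aryl group differs. No step beyond the scatter is therefore expected in this assay. The estimated move is a 1.4-fold lower number from compound 3 to compound 4 (0.15 log units; within the scatter), a small one in the lower direction. For compound 4 the estimated value is 8000 nM, with an expected range of 2500 nM to 25000 nM.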

Compound 4, half-maximal inhibitory concentration: 10100 nM
Compound 4: the middle estimate sits 1.3-fold (0.10 log units) below what was measured; the range from low to high includes it.
By their numbers in this assay, from the lowest: compounds 1, 4 and 3 (each within the scatter of the next). At a limit, above all of these: compound 2.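

In this assay, within the data shown here, hydroxy in place of hydrogen on an aromatic carbon gives a 1.1-fold lower number from compound 3 to compound 4 (0.05 log units; within the scatter); this is the first pair to isolate the change from benzyl to 3-hydroxybenzyl, and with the 4-nitrophenyl group in place the change stays within the scatter. With the 3-hydroxybenzyl held constant, the aryl exchange of 4-nitrophenyl in place of 3-chlorophenyl on an amide-type nitrogen gives a 1.7-fold higher number from compound 1 to compound 4 (0.24 log units; within the scatter), also within the scatter, whereas the exchange of the whole group on the amine nitrogen gives an at least 4.9-fold lower number from compound 2 to compound 4 (0.69 log units; beyond the scatter), which lies beyond it. That last step rests on compound 2, whose entry is a limit of the assay and not a number: the limit of > 50000 nM in this assay, at which 1 of the 4 values shown sits.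

Still open, on these data alone, is whether a methoxy, an amine or a carboxylic acid in place of the hydroxy on the benzyl group would move the number beyond the scatter. Also open is how the step involving compound 2 divides between its oxygen in place of sulfur and its second chlorine: no compound shown changes only one of them.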